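This account rests on a few compounds, and the source may have more. Where it says the series, first, only, none or still open, it means among the compounds named here.

In a functional assay on MCF7 cells (Homo sapiens) for antiproliferative activity, read by sulforhodamine B assay, with a stated time of 72 h (a higher number here means a weaker inhibitor, a lower number a stronger inhibitor), the series stands as follows:
- compound 1 (`O=C1NC(=O)/C(=C\c2ccc(-c3ccc(Cl)c(Cl)c3)o2)S1`) gives 14800 nM
- compound 2 (`CCCCOc1ccc(/C=C2\SC(=O)NC2=O)cc1`) gives "not determined" (no result reported)

For the measured compounds named here, compound 1 carries the only number so far, so its standing cannot be judged, and compound 2 offers no comparison. Compound 3 (`O=C1NC(=O)/C(=C\c2ccc(-c3ccc(F)c(Cl)c3)o2)S1`) departs from compound 1 in one place (fluoro in place of chloro on an aromatic carbon): fluoro in place of chloro on an aromatic carbon, ortho to a chloro group and para to a large group. Going by the values given here, no pair of measured compounds shows what such a change does. The expectation therefore rests on compound 1 (14800 nM) alone, and no shift beyond the scatter is expected in this assay in either direction. The expected change is small (a 1.1-fold higher number from compound 1 to compound 3 (0.03 log units; within the scatter)) and stays within the scatter. For compound 3 the estimated value is 16000 nM with an expected range from 7000 nM to 40000 nM in this measurement.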

Compound 3, half-maximal inhibitory concentration: 16900 nM
Estimate against measurement, compound 3: 1.1-fold (0.02 log units) below, and the stated range covers the measured number.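

In this assay, the first step read at this position, fluoro in place of chloro on an aromatic carbon, ortho to a chloro group and para to a large group, is a 1.1-fold higher number from compound 1 to compound 3 (0.06 log units; within the scatter) and so gives no readable shift. Compound 1 and compound 3 therefore read as equivalent, and at this position in the shared core, this assay does not separate the chloro group from the fluoro group. No measurement is available that bears on the reason for this result.

As far as these compounds go, whether an amine, a methoxy group or a carboxylic acid at this position would move the number beyond the scatter remains open. Also open, from the compounds shown here alone, is whether the same exchange at the remaining chloro group would leave the number equally unmoved.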